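The compounds below may be only part of what the source reports. "The series", "measured", "known", "first", "only" and "open" are said of these compounds alone.

Of the compounds shown here, three that share one core have been measured in a functional assay, with a stated time of 30 min, in the absence of a further agent; a lower number here means a stronger inhibitor, a higher number a weaker inhibitor. Compound 1 `Cc1ccc(C(=O)Nc2nnc(-c3ccc(O)c(O)c3)s2)cc1` gives 34000 nM. Compound 2 `O=C(Nc1nnc(-c2ccc(O)c(O)c2)s1)C1CCCCC1` gives 37300 nM. Compound 3 `O=C(Nc1nnc(-c2ccc(O)c(O)c2)s1)c1ccc(Cl)cc1` gives 53000 nM. The step of a 1.6-fold higher number from compound 1 to compound 3 (0.19 log units; within the scatter) and the step of a 1.4-fold higher number from compound 2 to compound 3 (0.15 log units; within the scatter) both lie within the scatter, so compound 3 stands level with compound 1 and compound 2 rather than apart from them.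

Compound 4 `CC(=O)Nc1nnc(-c2ccc(O)c(O)c2)s1` has not yet been measured. It differs from compound 3 in one place: methyl in place of 4-chlorophenyl on a carbonyl carbon. Among the compounds with values here, two measured steps bear on a swap of the group on the carbonyl carbon. The step of a 1.1-fold higher number from compound 1 to compound 2 (0.04 log units; within the scatter) exchanged 4-methylphenyl for cyclohexyl, and the step of a 1.4-fold higher number from compound 2 to compound 3 (0.15 log units; within the scatter) exchanged cyclohexyl for 4-chlorophenyl; neither moved the number beyond the scatter. No measured step removes the ring at this position altogether, so the change to methyl reaches further than anything shown, and the uncertainty is wider than those two steps alone suggest.

The expected outcome in this assay is therefore a step of a 1.1-fold lower number from compound 3 to compound 4 (0.03 log units; within the scatter), with no firm ground for a shift beyond the scatter in either direction. Compound 4 is estimated to give about 50000 nM, most likely between 18000 nM and 150000 nM.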

Compound 4, half-maximal inhibitory concentration: 23400 nM
Estimate against measurement, compound 4: 2.1-fold (0.33 log units) above; the range from low to high includes it.
By their numbers in this assay, from the lowest: compounds 4, 1, 2 and 3 (each within the scatter of the next, the first and the last beyond it).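

In this assay, within the data shown here, the ring on the carbonyl carbon proves dispensable: with the 4-chlorophenyl group and its 7 heavy atoms replaced by a single methyl carbon, the result is a 2.3-fold lower number from compound 3 to compound 4 (0.36 log units; beyond the scatter), the first change of group on this carbonyl carbon to pass the scatter, and it runs toward a stronger inhibitor rather than a weaker one. The same methyl set against the other two groups gives a 1.6-fold lower number from compound 2 to compound 4 (0.20 log units; within the scatter) and a 1.5-fold lower number from compound 1 to compound 4 (0.16 log units; within the scatter), so methyl stands apart only from 4-chlorophenyl, and this modest difference rests on that single comparison. Nothing measured here gives a reason for the step.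

The compounds shown leave open what a longer chain such as ethyl or propyl, or a chain ending in an amine or a carboxylic acid, would do on this carbonyl carbon, as the groups here are only methyl and the three six-membered rings. Going by these compounds, the shared core stays the same in all four compounds, so the effect of any change to it also remains open.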